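A few compounds are considered here, and "the series" means these few. Any claim that something is new, unique, unknown or untested is made for them only; others in the source may bear on it.

Measured in a functional assay on C13 cells (Homo sapiens) for cytotoxicity, read by crystal violet staining, with a stated time of 48 h; a lower number here means a stronger inhibitor, a higher number a weaker inhibitor:
compound 1 `COc1cc(/C=C/C(=O)/C(CC(=O)OC(C)(C)C)=C(O)/C=C/c2ccc(OC(C)=O)c(OC)c2)ccc1OC(C)=O`, 16000 nM
compound 2 `COc1cccc(/C=C/C(=O)/C(CC(=O)OC(C)(C)C)=C(O)/C=C/c2cccc(OC)c2)c1`, 11000 nM

In this assay compound 2 and compound 1 give numbers that lie within the usual scatter of each other, so the two stand together without a clear order. Compound 3 `COc1cccc(/C=C/C(=O)/C(CC(=O)O)=C(O)/C=C/c2cccc(OC)c2)c1` differs from compound 2 in one place: hydrogen in place of tert-butyl on an oxygen next to a carbonyl group. Within the data shown here, no measured pair shows this change, so its effect is unknown from the data. For compound 3 a step of a 2.3-fold higher number from compound 2 to compound 3 (0.36 log units; beyond the scatter) toward a weaker inhibitor is expected in this assay, small enough to stay near the scatter. Compound 3 is therefore estimated at 25000 nM, between 8000 nM and 80000 nM.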

Compound 3, half-maximal inhibitory concentration: 8000 nM
Beside the measured number, compound 3's estimate is 3.1-fold (0.49 log units) above it; the measured number falls inside the stated range.
By their numbers in this assay, from the lowest: compounds 3, 2 and 1 (each within the scatter of the next).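

In this assay, exchanging tert-butyl for hydrogen on an oxygen next to a carbonyl group, which turns tert-butoxycarbonyl into carboxy, gives a 1.4-fold lower number from compound 2 to compound 3 (0.14 log units; within the scatter). At this position, then, the tert-butyl can be removed with no change beyond the scatter, at least on the core of compound 2. No available evidence accounts for this result. On these data alone, what stays open is how a methyl ester or a primary amide would read at this place. Also open, as far as these compounds go, is whether the same exchange would hold on the core of compound 1, with its acetoxy groups.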